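A few compounds are considered here, and "the series" means these few. Any claim that something is new, unique, unknown or untested is made for them only; others in the source may bear on it.

Compound 1 `N#Cc1ccc(/C=N/NC(=O)Nc2cc3c(Nc4ccc(F)c(Cl)c4)ncnc3cc2O[C@H]2CCOC2)cc1`: 28100 nM
Compound 2 `O=C(N/N=C/c1cccc(Cl)c1Cl)Nc1cc2c(Nc3ccc(F)c(Cl)c3)ncnc2cc1O[C@H]1CCOC1`: 27400 nM

In a functional assay on PC-3 cells (Homo sapiens) for cytotoxicity, read by MTT assay, with a stated time of 72 h (on this read-out lower numbers stand for stronger inhibition and higher numbers for weaker inhibition), compound 1 gives 28100 nM and compound 2 gives 27400 nM, so the two stand level. Among the compounds with values here, the only measured step, a 1.0-fold lower number from compound 1 to compound 2 (0.01 log units; within the scatter), puts 2,3-dichlorophenyl in place of 4-cyanophenyl on a carbon with a double bond to nitrogen, and it stays within the scatter.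

Compound 3 `COc1ccc(/C=N/NC(=O)Nc2cc3c(Nc4ccc(F)c(Cl)c4)ncnc3cc2O[C@H]2CCOC2)cc1` has not yet been measured. It keeps the core of compound 1 and changes one group: methoxy in place of cyano on an aromatic carbon. In words, this is methoxy in place of cyano on an aromatic carbon, para to a large group, so 4-cyanophenyl becomes 4-methoxyphenyl.

Within the data shown here, no tested compound carries methoxy, so the evidence is thin and indirect. Compound 2, at 27400 nM, shows only that one other replacement of the 4-cyanophenyl group left the number in place. No step beyond the scatter is therefore expected in this assay, in either direction. The expected change is a 1.0-fold lower number from compound 1 to compound 3 (0.02 log units; within the scatter). For compound 3 the estimated value is 27000 nM, with an expected range from 13000 nM to 50000 nM.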

Compound 3, half-maximal inhibitory concentration: 34100 nM
The estimate for compound 3 lay 1.3-fold (0.10 log units) below the measured number, within the range that was stated.
By their numbers in this assay, from the lowest: compounds 2, 1 and 3 (each within the scatter of the next).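

Placing methoxy directly on the ring carbon that held the nitrile in compound 1 gives, in this assay, a 1.2-fold higher number from compound 1 to compound 3 (0.08 log units; within the scatter), so this exchange, which leaves the count of heavy atoms and of hydrogen-bond acceptors unchanged but removes a triple bond, does not move the number beyond the scatter. The second comparison, a 1.2-fold higher number from compound 2 to compound 3 (0.10 log units; within the scatter), links the new 4-methoxyphenyl group to the 2,3-dichlorophenyl group, and it too stays within the scatter, so the 4-cyanophenyl, 2,3-dichlorophenyl and 4-methoxyphenyl versions cannot be told apart here. No measurement available here accounts for this agreement among the three groups.

These three compounds leave open whether a very different group on this ring, such as a primary amine, a carboxylic acid or a longer chain like butoxy, would give a number clearly separate from these. They also leave open how a plain unsubstituted phenyl ring would read, and whether the same agreement among the three groups would hold on cells other than those used here.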